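The compounds below may be only part of what the source reports. "The series", "measured", "known", "first", "only" and "open" are said of these compounds alone.

Measured compounds in an assay for binding affinity to leukotriene B4 receptor 1 (Homo sapiens); a higher number here means a weaker inhibitor, a lower number a stronger inhibitor:

compound 1 `CCCCCCCCCCCCOc1ccc(C[S+]([O-])c2cccc(C(=O)O)c2)nc1/C=C/C(=O)O` — 129 nM
compound 2 `COc1ccc(CCCCCCCCOc2ccc(COc3cccc(C(=O)O)c3)[n+]([O-])c2/C=C/C(=O)O)cc1` — 150 nM
compound 3 `COc1ccc(CCCCCCCCOc2ccc(C[S+]([O-])c3cccc(C(=O)O)c3)nc2/C=C/C(=O)O)cc1` — 151 nM

Compound 3 holds the highest of the three numbers in this assay, yet its gap to compound 2 and its gap to compound 1 both lie within the scatter, so the three measured compounds cannot be told apart on these numbers. Among the measured compounds shown here, the only step between two measured compounds that differ in one place is a 1.2-fold higher number from compound 1 to compound 3 (0.07 log units; within the scatter); it sits at the far end of the chain, eight bonds from the aromatic oxygen, and changes nothing beyond the scatter.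

Compound 4 `COc1ccc(CCCCCCCCOc2ccc(C[S+]([O-])c3cccc(N)c3)nc2/C=C/C(=O)O)cc1` is the next compound in the series. Relative to compound 3 the change is amino in place of carboxy on an aromatic carbon. For the measured compounds named here, no measured step touches this position: the step from compound 1 to compound 3 concerns the chain end only and says nothing about the carboxy on the phenyl ring. The expectation therefore rests on the structural change alone; exchanging a carboxy for an amino on this ring is expected to move the number well beyond the scatter toward weaker binding, the expected step being a 9.9-fold higher number from compound 3 to compound 4 (1.00 log units; beyond the scatter). Compound 4 is estimated at 1500 nM, with a range from 300 nM to 8000 nM.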

Compound 4, inhibition constant: 4.7 nM
Compound 4: middle estimate off by 320-fold (2.50 log units), on the high side; the measured number lies below the stated range.
By their numbers in this assay, from the lowest: compound 4; then compounds 1, 2 and 3 (each within the scatter of the next).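

In this assay, among the compounds shown here, the exchange of 3-carboxyphenyl for 3-aminophenyl gives a 32-fold lower number from compound 3 to compound 4 (1.51 log units; beyond the scatter), making this place, on an aromatic carbon meta to a large group, the first where a single change moves the number beyond the scatter; the one earlier step, at the far end of the chain, did not. With the shared core and the 4-methoxyphenyl chain end of compound 3, the carboxy on this ring is therefore not required for a low number, and an amino group with no acid on the ring serves far better here. No measurement available here bears on the reason for this large step.

Open, as far as these compounds go, is whether the lower number comes from the amino group itself or from the loss of the carboxy: a plain hydrogen, a hydroxy, a methylamino or an acetamido group at this place would separate the two. Also open, from the compounds shown here alone, is whether the same exchange gives a step of similar size with the chain end of compound 1.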